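The source may report more compounds than this note shows. Statements on the series, on what has been measured and on what is new or still open speak of the compounds shown alone.

Measured in a functional assay on BJAB cells (Homo sapiens) for antiproliferative activity, with a stated time of 4 days; on this read-out lower numbers stand for an effect already at smaller amounts and higher numbers for an effect only at larger amounts of compound:

compound 1 `Cc1c(-c2cc(Cl)cc(Cl)c2)c(C(=O)O)nn1-c1nc(-c2cc(Cl)ccc2F)c(SC(C)C)s1` gives 4800 nM
compound 2 `COc1cncc(-c2c(C)nn(-c3nc(-c4ccc(Cl)c(Cl)c4)c(SC(C)C)s3)c2C(=O)O)c1` gives 21000 nM
compound 3 `Cc1nn(-c2nc(-c3ccc(Cl)c(Cl)c3)c(SC(C)C)s2)c(C(=O)O)c1-c1cc(C(F)(F)F)cc(C(F)(F)F)c1` gives 1800 nM

Among these three, compound 2 stands at the highest number. Its nearest neighbour is compound 1, whose value in this assay is lower by a margin beyond the scatter, and compound 3 lies furthest from it, lower still and likewise beyond the scatter. Going by the values given here, none of these three pairs differs in a single place, so the three values show only that compound 2 is the weakest of the set.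

Compound 4 `Cc1cccc(-c2c(C)nn(-c3nc(-c4ccc(Cl)c(Cl)c4)c(SC(C)C)s3)c2C(=O)O)c1` is the one-place variant of compound 2: 3-methylphenyl in place of 5-methoxypyridin-3-yl on an aromatic carbon. Among the compounds with values here, with no single-change pair measured, the size of this step cannot be read from the data. The two compounds that give lower numbers than compound 2, compound 1 with 4800 nM and compound 3 with 1800 nM, both carry a carbon-only ring rather than a heteroaryl at that place, so compound 4 is expected to move downward by a 3.8-fold lower number from compound 2 to compound 4 (0.58 log units; beyond the scatter), beyond the scatter. Compound 4 is therefore estimated at 5500 nM, within 1500 nM to 18000 nM.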

Compound 4, half-maximal effective concentration: 17000 nM
Beside the measured number, compound 4's estimate is 3.1-fold (0.49 log units) below it; measured number inside the range.
By their numbers in this assay, from the lowest: compound 3; then compound 1; then compounds 4 and 2 (each within the scatter of the next).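

In this assay, going by these compounds alone, a 1.2-fold lower number from compound 2 to compound 4 (0.09 log units; within the scatter) is the first single-change step at this place, on an aromatic carbon of the five-membered ring, and it lies within the scatter. In this pair, exchanging 5-methoxypyridin-3-yl for 3-methylphenyl removes the ring nitrogen, the oxygen and both hydrogen-bond acceptors without a readable difference, so a carbon-only ring alone does not give a lower number here. Nothing shown offers a reason for this result.

The compounds shown leave open whether a group of another kind at this place, such as an amine on the ring or a saturated cyclohexyl ring, would give a number beyond the scatter. They also leave open whether this step would be the same size with a different group on the rest of the core.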